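Branching the Alkyl Chain of Compound 1

The compounds below may be only part of what the source reports. "The series", "measured", "known", "first", "only" and "open" are said of these compounds alone.

Compound 1, `CCCCCOCNc1n[n+]([O-])c2ccccc2[n+]1[O-]`, gives 8510 nM in a functional assay on PC-3 cells (Homo sapiens) for cytotoxicity, read by MTT assay, with a stated time of 72 h; a lower number here means a stronger inhibitor, a higher number a weaker inhibitor.
Compound 2, `[O-][n+]1nc(NCOCc2ccc(C(F)(F)F)cc2)[n+]([O-])c2ccccc21`, gives 9310 nM in this assay.
Compound 3, `CCCCCOCNc1n[n+]([O-])c2cc(OC)ccc2[n+]1[O-]`, gives 30900 nM in this assay.

Compound 1 holds the lowest of the three numbers, though compound 2 lies within the scatter of it. Among the compounds with values here, the one measured step, a 3.6-fold higher number from compound 1 to compound 3 (0.56 log units; beyond the scatter), concerns the aromatic ring and not the chain. Compound 4, `CC(C)CCOCNc1n[n+]([O-])c2ccccc2[n+]1[O-]`, differs from compound 1 in one place: isopropyl in place of propyl on a saturated chain carbon, two bonds along the chain from an oxygen on a saturated carbon. Within the data shown here, no measured step touches the saturated chain, so nothing here speaks for a change in either direction, and the step of a 1.0-fold lower number from compound 1 to compound 4 (0.00 log units; within the scatter) is expected to stay within the scatter. Compound 4 is therefore estimated to give 8500 nM in this assay, with a range from 4000 nM to 18000 nM.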

Compound 4, half-maximal inhibitory concentration: 7520 nM
Beside the measured number, compound 4's estimate is 1.1-fold (0.05 log units) above it; the measured number falls inside the stated range.
By their numbers in this assay, from the lowest: compounds 4, 1 and 2 (each within the scatter of the next); then compound 3.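

In this assay, the saturated chain now has a measured step of its own (a 1.1-fold lower number from compound 1 to compound 4 (0.05 log units; within the scatter)). At this position, two bonds along the chain from an oxygen on a saturated carbon, isopropyl in place of propyl leaves the number within the scatter, whereas the earlier measured step concerned the aromatic ring. No available evidence bears on this result.

The compounds shown leave open whether a longer chain, a cyclohexyl group or an amine at this position would move the number beyond the scatter. They also leave open whether isopropyl in place of propyl gives the same result alongside the methoxy group of compound 3.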